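Replacing dimethylcarbamoyl with 1,2,4-oxadiazol-3-yl in a clearance series

The source may report more compounds than this note shows. Statements on the series, on what has been measured and on what is new or still open speak of the compounds shown alone.

In an in vivo ADME assay on the whole organism (strain 129/SvEvBrd x C57BL/6) for pharmacokinetics, with Mus musculus as the target, at a dose of 1 mg/kg by the intravenous route (on this read-out lower numbers stand for slow clearance and higher numbers for fast clearance), compound 1 (`CC(=O)c1cccc([C@@H](O)[C@H](O)[C@H](O)CO)n1`) gives 14 mL/min/kg and compound 2 (`CC(=O)c1nc([C@@H](O)[C@H](O)[C@H](O)CO)c(C)[nH]1`) gives 7 mL/min/kg. Compound 3 (`CN(C)C(=O)c1nc([C@@H](O)[C@H](O)[C@H](O)CO)c[nH]1`) gives 11.3 mL/min/kg, which lies within the scatter of both compound 1 and compound 2. Compound 4 (`OC[C@@H](O)[C@@H](O)[C@H](O)c1c[nH]c(-c2ncon2)n1`) carries 1,2,4-oxadiazol-3-yl in place of dimethylcarbamoyl on an aromatic carbon. Within the data shown here, no measured pair differs in one place only, so the data offer no direct guide to this change. In this assay, no step beyond the scatter is expected, in either direction. The estimated step is a 1.1-fold lower number from compound 3 to compound 4 (0.05 log units; within the scatter). For compound 4 the expected clearance is 10 mL/min/kg, with an estimated range of 5 mL/min/kg to 20 mL/min/kg.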

Compound 4, clearance: 11.3 mL/min/kg
For compound 4 the middle estimate is 1.1-fold (0.05 log units) below the measured one; measured number inside the range.
By their numbers in this assay, from the lowest: compounds 2, 3, 4 and 1 (each within the scatter of the next).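

In this assay, the first pair differing in one place shows no change at the digits printed from compound 3 to compound 4 (within the scatter) when 1,2,4-oxadiazol-3-yl takes the place of dimethylcarbamoyl on an aromatic carbon between two ring nitrogen atoms. At this position, an open group and a five-membered aromatic ring, each of 5 heavy atoms, thus give matching clearance despite 1 and 3 hydrogen-bond acceptors. Nothing available explains this match.

As far as these compounds go, whether an amine or a carboxylic acid at this position would also leave clearance unchanged remains open. So does whether 1,2,4-oxadiazol-3-yl would behave alike on the cores of compound 1 and compound 2.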